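The source may hold more compounds than are shown below. What is called first, only, known or untested is meant among the compounds shown, and "the series" means these compounds.

Measured compounds:
Compound 1, `COc1nc2ccc(Br)cc2cc1C(c1ccccc1)n1cc(-c2ccccc2F)nn1`: 7.33%
Compound 2, `CCCCc1cn(C(c2ccccc2)c2cc3cc(Br)ccc3nc2OC)nn1`: 11.1%
Compound 3, `COc1nc2ccc(Br)cc2cc1C(c1ccccc1)n1cc(-c2ccc(OC(F)(F)F)cc2)nn1`: 14.8%

All three were run in an ADME assay on SK-OV-3 cells (Homo sapiens) for cytotoxicity, read by sulforhodamine B assay, with a stated time of 48 h, tested at 10 uM; a higher number here means more inhibition at the concentration tested (going by the name of the read-out), a lower number less inhibition. Going by the values given here, the three numbers sit close together: the step of a number 3.8 percentage points higher from compound 1 to compound 2 (within the scatter), the step of a number 7.5 percentage points higher from compound 1 to compound 3 (within the scatter) and the step of a number 3.7 percentage points higher from compound 2 to compound 3 (within the scatter) are each within the scatter, so no compound separates itself from the others in this assay. Compound 3 stands at the end of both steps that lead to it, but neither step is beyond the scatter, so it is not distinguished from compound 1 or compound 2 on these data.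

Compound 4, `COc1nc2ccc(Br)cc2cc1C(c1ccccc1)n1cc(CCO)nn1`, has not yet been measured in this assay. It differs from compound 3 in one place: 2-hydroxyethyl in place of 4-(trifluoromethoxy)phenyl on an aromatic carbon. Among the compounds with values here, the steps that bear on this change are those in which the group on the same aromatic carbon was exchanged, 2-fluorophenyl for butyl, 2-fluorophenyl for 4-(trifluoromethoxy)phenyl, and butyl for 4-(trifluoromethoxy)phenyl; all three stayed within the scatter. The 2-hydroxyethyl group is not represented among the measured compounds, so nothing shown points to a step beyond the scatter in either direction. Compound 4 is therefore expected to give about 9% in this assay, within 0% to 22%. The expected step is a number 5.8 percentage points lower from compound 3 to compound 4 (within the scatter), estimated to be within the scatter.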

Compound 4, a percentage reported as inhibition, at one concentration (the size of the read-out at that concentration, not a potency): 8.46%
The estimate for compound 4 lay 0.5 percentage points above the measured number; measured number inside the range.
By their numbers in this assay, from the lowest: compounds 1, 4, 2 and 3 (each within the scatter of the next).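

In this assay the aromatic carbon of the five-membered ring with 3 nitrogen now carries a group with no ring and 1 hydrogen-bond donor, and the exchange of 4-(trifluoromethoxy)phenyl, with 11 heavy atoms, for 2-hydroxyethyl, with 3 heavy atoms, stays within the scatter (a number 6.3 percentage points lower from compound 3 to compound 4 (within the scatter)). The other two exchanges at this position also stay within the scatter: hydroxy in place of ethyl on the saturated chain of the butyl group (a number 2.6 percentage points lower from compound 2 to compound 4 (within the scatter)) and 2-hydroxyethyl in place of 2-fluorophenyl (a number 1.1 percentage points higher from compound 1 to compound 4 (within the scatter)), so all four compounds, with aromatic, plain chain and hydroxy-bearing chain groups, are not separated at this position. No supporting data on this result are available to explain the flat picture.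

As far as these compounds go, whether an amine, a carboxylic acid or a chain longer than 2-hydroxyethyl on the same aromatic carbon would give a step beyond the scatter remains open. From the compounds shown here alone, all four compounds share one core and one test concentration, so the behaviour of this position on another core, and the size of the effect at any other concentration, also remain open.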